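A few compounds are considered here, and "the series" means these few. Any claim that something is new, unique, unknown or untested is made for them only; others in the source may bear on it.

Working notes on the series. Three analogues on one shared core have been measured; what varies is the aryl group on an aromatic carbon next to the ring nitrogen, ortho to a cyano group. Compound 1 `CCOC(=O)c1cnn(-c2nc(-c3cccc(OC)c3OC)c(C#N)c(=O)n2C)c1N` carries 2,3-dimethoxyphenyl, and in a functional assay, with a stated time of 20 min (on this read-out higher numbers stand for weaker inhibition and lower numbers for stronger inhibition), compound 1 gives 54 ug/mL. Compound 2 `CCOC(=O)c1cnn(-c2nc(-c3ccccc3O)c(C#N)c(=O)n2C)c1N` carries 2-hydroxyphenyl; compound 2 gives 48 ug/mL. Compound 3 `CCOC(=O)c1cnn(-c2nc(-c3ccc(N(C)C)cc3)c(C#N)c(=O)n2C)c1N` carries 4-(dimethylamino)phenyl; compound 3 gives 98 ug/mL, the highest of the three numbers: a 1.8-fold higher number from compound 1 to compound 3 (0.26 log units; within the scatter), and a 2.0-fold higher number from compound 2 to compound 3 (0.31 log units; beyond the scatter), the latter a modest step beyond the scatter.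

Compound 4 `CCOC(=O)c1cnn(-c2nc(-c3cccc(O)c3O)c(C#N)c(=O)n2C)c1N` is not yet measured. The change is 2,3-dihydroxyphenyl in place of 4-(dimethylamino)phenyl on an aromatic carbon. The entering group shares the two oxygen substituents of compound 1 and the free hydroxyl of compound 2, so the two steps ending at compound 3 bear on it, read in reverse; both point to a small-to-modest decrease. The step is expected to be a 2.0-fold lower number from compound 3 to compound 4 (0.29 log units; within the scatter). Compound 4 is therefore estimated at 50 ug/mL, with a range from 25 ug/mL to 100 ug/mL.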

Compound 4, half-maximal inhibitory concentration: 41 ug/mL
Estimate against measurement, compound 4: 1.2-fold (0.09 log units) above, within the range that was stated.
By their numbers in this assay, from the lowest: compounds 4, 2, 1 and 3 (each within the scatter of the next, the first and the last beyond it).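

In this assay, 2,3-dihydroxyphenyl gives a 2.4-fold lower number from compound 3 to compound 4 (0.38 log units; beyond the scatter), so compound 3 now stands apart from compound 2 and compound 4, though still not from compound 1. Neither the added hydroxy, a 1.2-fold lower number from compound 2 to compound 4 (0.07 log units; within the scatter), nor the exchange of 2,3-dimethoxyphenyl for 2,3-dihydroxyphenyl, a 1.3-fold lower number from compound 1 to compound 4 (0.12 log units; within the scatter), carries the number beyond the scatter, so compound 1, compound 2 and compound 4 cannot be told apart on this read-out. Nothing measured on these compounds accounts for these steps.

Still open, from the compounds shown here alone, is whether the gap to compound 3 follows the dimethylamino group itself or its place on the phenyl ring, which a 4-hydroxyphenyl or a 2-(dimethylamino)phenyl group would separate. Also open, going by these compounds, is what a carboxylic acid on the phenyl ring, or a pyridyl ring in its stead, would give.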